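The compounds below may be only part of what the source reports. "The series", "measured", "known", "first", "only" and "open" are said of these compounds alone.

The measured compounds, with their numbers in an assay on isolated protein for inhibition of kynurenine--oxoglutarate transaminase 1 (Homo sapiens), read by HPLC, with a stated time of 20 min; on this read-out lower numbers stand for stronger inhibition and higher numbers for weaker inhibition:
compound 1 `CCOC(=O)/C(CCCC(=O)O)=N\Nc1ccc(Cl)cc1` gives 20000 nM;
compound 2 `CCOC(=O)/C(CCCC(=O)O)=N\Nc1ccc(OC)cc1` gives 43000 nM;
compound 3 `CCOC(=O)/C(CCCC(=O)O)=N\Nc1ccc([N+](=O)[O-])cc1` gives 179000 nM.

Compound 3 stands at the highest, that is weakest, of the three numbers, shown by a 9.0-fold higher number from compound 1 to compound 3 (0.95 log units; beyond the scatter) and by a 4.2-fold higher number from compound 2 to compound 3 (0.62 log units; beyond the scatter). Compound 4 `CCOC(=O)/C(CCCC(=O)O)=N\Nc1ccc(C)cc1` differs from compound 3 by methyl in place of nitro on an aromatic carbon. Among the compounds with values here, no measured step swaps nitro directly for methyl; the steps that bear on it are the two in which nitro entered, a 9.0-fold higher number from compound 1 to compound 3 (0.95 log units; beyond the scatter) and a 4.2-fold higher number from compound 2 to compound 3 (0.62 log units; beyond the scatter), both modest rises. Taking the nitro away again is therefore expected to lower the number in this assay by a modest step. The estimated step is a 5.1-fold lower number from compound 3 to compound 4 (0.71 log units; beyond the scatter). Compound 4 is expected to give about 35000 nM, within 12000 nM to 100000 nM.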

Compound 4, half-maximal inhibitory concentration: 33000 nM
Estimate against measurement, compound 4: 1.1-fold (0.03 log units) above, and the stated range covers the measured number.
By their numbers in this assay, from the lowest: compounds 1, 4 and 2 (each within the scatter of the next, the first and the last beyond it); then compound 3.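

Swapping nitro for methyl gives a 5.4-fold lower number from compound 3 to compound 4 (0.73 log units; beyond the scatter) in this assay, which leaves nitro as the only one of the four groups at this ring position set clearly apart. Methyl cannot be told from methoxy (a 1.3-fold lower number from compound 2 to compound 4 (0.11 log units; within the scatter)) or from chloro (a 1.7-fold higher number from compound 1 to compound 4 (0.22 log units; within the scatter)), even though methoxy and chloro differ beyond the scatter, so methyl does not separate them. Nothing measured here explains why nitro stands apart. Still open, as far as these compounds go, is what an amine or a bromo group on this carbon would give, and whether a longer chain elsewhere on the shared core would shift the number further.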